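Pyridin-3-yl for Furan-3-yl on the Shared Core

The source may hold more compounds than are shown below. What is called first, only, known or untested is meant among the compounds shown, and "the series" means these compounds.

Compound 2 `Oc1ccccc1-c1cc(-c2ccoc2)cc(-c2ccccc2O)n1` has been measured in a functional assay on DU-145 cells (Homo sapiens) for cytotoxicity, read by CCK-8 assay (a higher number here means a weaker inhibitor, a lower number a stronger inhibitor), where compound 2 gives > 50000 nM, which is a limit of the assay and not a number. Compound 1 `Oc1ccccc1-c1cc(-c2ccsc2)cc(-c2ccccc2O)n1` likewise sits at a limit, giving > 50000 nM. Compound 3 `Oc1cccc(-c2cc(-c3ccoc3)cc(-c3ccccc3O)n2)c1` is the only one of the three to give a number in this assay, 2790 nM. Compound 2 therefore stands at the limit, as the limit of > 50000 nM in this assay, at which 2 of the 3 values shown sit, records. The step that the two limits leave unreadable from compound 1 to compound 2 has a limit at each end and cannot be read. The step of an at least 17-fold lower number from compound 2 to compound 3 (1.25 log units; beyond the scatter) is large, but it concerns the 2-hydroxyphenyl group rather than the five-membered ring. Compound 4 `Oc1ccccc1-c1cc(-c2cccnc2)cc(-c2ccccc2O)n1` differs from compound 2 by pyridin-3-yl in place of furan-3-yl on an aromatic carbon. Within the data shown here, the only measured step touching the same place, a step that the two limits leave unreadable from compound 1 to compound 2, is unreadable, so nothing measured indicates the direction or size of the step to compound 4 in this assay; what is known is that compound 2 sits at the limit. Compound 4 is expected to remain near that limit, with the step of a number no higher from compound 2 to compound 4 (the limit leaves the size open) estimated as the likeliest outcome. Compound 4 is estimated at 50000 nM, between 10000 nM and 200000 nM.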

Compound 4, half-maximal inhibitory concentration: > 50000 nM
Compound 4 gave a limit, no number; the forecaster's own chance of this, stated with the estimate: 65%; the middle value lies on the limit itself.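

Compound 4, like compound 1 and compound 2, gives a limit and not a number, and no new step among these three compounds can be read. The compounds shown leave open whether pyridin-3-yl, furan-3-yl and thiophen-3-yl differ at all in this assay on the shared core.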